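The source may hold more compounds than are shown below. What is called first, only, known or untested is meant among the compounds shown, and "the series" means these compounds.

Measured so far:
compound 1 `CN(C[C@H]1Cc2c(cccc2N2C[C@H]3CNC[C@H]3C2)CN1)[C@H]1CCCc2cccnc21` gives 10.3 nM in a functional assay on CCRF-CEM cells for antagonist activity at C-X-C chemokine receptor type 4 (Homo sapiens), read by calcium flux, with stated times of 25 min and 90 s; on this read-out lower numbers stand for stronger inhibition and higher numbers for weaker inhibition
compound 2 `CN(C)[C@H]1CCN(c2cccc3c2C[C@H](CN(C)[C@H]2CCCc4cccnc42)NC3)C1` gives 10.9 nM in this assay

On these two numbers compound 2 sits alongside compound 1, the gap being a 1.1-fold higher number from compound 1 to compound 2 (0.02 log units; within the scatter). Compound 3 `CN(C)[C@@H]1CCN(c2cccc3c2C[C@H](CN(C)[C@H]2CCCc4cccnc42)NC3)C1` has the same atoms and bonds as compound 2: the two compounds have the same atoms and bonds and differ only in configuration as drawn: 1 of 3 stereo elements differ; a stereocentre at a saturated ring carbon is drawn S in compound 2 and R in compound 3. For the measured compounds named here, the only measured step, from compound 1 to compound 2, exchanges one group for another and tells nothing about flipping a stereocentre, so no measured step bears on this change; no step beyond the scatter is assumed in this assay, only wide uncertainty. Compound 3 is therefore expected to give 13 nM (range 4 nM to 60 nM), an estimated step of a 1.2-fold higher number from compound 2 to compound 3 (0.08 log units; within the scatter).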

Compound 3, half-maximal inhibitory concentration: 10.4 nM
The estimate for compound 3 lay 1.3-fold (0.10 log units) above the measured number; the range from low to high includes it.
By their numbers in this assay, from the lowest: compounds 1, 3 and 2 (each within the scatter of the next).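

Drawing the stereocentre at this saturated ring carbon as R rather than S gives a 1.0-fold lower number from compound 2 to compound 3 (0.02 log units; within the scatter) in this assay, so this read-out does not separate the two configurations at this position. The comparison concerns this stereocentre alone: the fact that compounds 2 and 3 differ only in the configuration as drawn. With the R configuration, the one-ring group also stays within the scatter of the group with two five-membered rings (a 1.0-fold higher number from compound 1 to compound 3 (0.00 log units; within the scatter)). The compounds shown leave open how a carboxylic acid or a longer chain on this aromatic carbon would read.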